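Trifluoromethyl for methyl on the aryl ring: a repeated change

A few compounds are considered here, and "the series" means these few. Any claim that something is new, unique, unknown or untested is made for them only; others in the source may bear on it.

Three compounds share the same kind of three-part build: an acid-bearing phenyl ring, a linking ether and a five-membered heteroaromatic ring that carries a second aryl ring. Compound 1 `Cc1cccc(-c2noc(COc3ccc(CCC(=O)O)cc3Cl)n2)c1` and compound 2 `O=C(O)CCc1ccc(OCc2nc(-c3cccc(C(F)(F)F)c3)no2)c(Cl)c1` have a chloro on the acid-bearing ring; compound 3 `Cc1ccc(-c2noc(COc3ccc(CCC(=O)O)cc3)n2)cc1` does not. Compound 4 `O=C(O)CCc1ccc(OCc2nc(-c3ccc(C(F)(F)F)cc3)no2)cc1` has not yet been measured.

In a functional assay on CHO cells for agonist activity at Free fatty acid receptor 1 (Homo sapiens), read by FLIPR and calcium flux, in the presence of a further agent that is not named here (a higher number here means that more compound is needed for the effect, a lower number that less compound is needed), compound 1 gives 4580 nM, while compound 2 gives 30100 nM. The change between them is trifluoromethyl in place of methyl on an aromatic carbon, and it produced a 6.6-fold higher number from compound 1 to compound 2 (0.82 log units; beyond the scatter). Compound 3 gives 300 nM in this assay, the lowest number of the three measured; the difference between its core and the core of compound 1 is not broken down here.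

The change from compound 3 to compound 4 is trifluoromethyl in place of methyl on an aromatic carbon. It is the same kind of change as that from compound 1 to compound 2, but not the same: in compound 2 the entering group sits meta to a large group, whereas in compound 4 it sits para to a large group. Among the compounds with values here, because the only measured example of this change gave a 6.6-fold higher number from compound 1 to compound 2 (0.82 log units; beyond the scatter), a higher number for compound 4 than for compound 3 is expected, though the different place on the ring leaves room for a smaller or larger shift. The expected step is a 5.0-fold higher number from compound 3 to compound 4 (0.70 log units; beyond the scatter). Compound 4 is therefore estimated at 1500 nM in this assay, with a range from 400 nM to 6000 nM.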

Compound 4, half-maximal effective concentration: 610 nM
Compound 4: middle estimate off by 2.5-fold (0.39 log units), on the high side; low and high end bracket the measured number.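

In both pairs, putting trifluoromethyl in place of methyl raises the number in this assay, and in the new pair the change gives a 2.0-fold higher number from compound 3 to compound 4 (0.31 log units; beyond the scatter). The direction of the change therefore carries over between these two cores, but its size does not, so the step seen on one core would not have given an exact figure for the other: the same change on two cores in this assay, a 6.6-fold higher number (0.82 log units; beyond the scatter) from compound 1 to compound 2 and a 2.0-fold higher number (0.31 log units; beyond the scatter) from compound 3 to compound 4, 3.2-fold (0.51 log units) apart, beyond the scatter of two such steps These two pairs do not show what sets the size of the step, as they differ in more than one way: compound 1 and compound 2 carry a chloro on the acid-bearing ring, while compound 3 and compound 4 do not, and the entering group also sits at a different place on the aryl ring in each pair.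

The compounds shown leave open whether the chloro, the place on the ring or both account for the gap between the two steps, and a pair with the chloro and the group para to a large group would separate these. Also open, as far as these compounds go, is how other groups at the same place on the ring, such as a nitrile, a methoxy group or a single fluorine, would compare with methyl and trifluoromethyl.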